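This account rests on a few compounds, and the source may have more. Where it says the series, first, only, none or still open, it means among the compounds named here.

Measured compounds:
Compound 1 `O=C(CCCc1ccccc1)Nc1nc2ccc(Cl)cc2c(=O)s1` — > 10000 nM
Compound 2 `O=C(CCCc1ccccc1)Nc1nc2ccccc2c(=O)s1` — 229 nM
Compound 3 `O=C(CCCc1ccccc1)Nc1nc2ccc(Br)cc2c(=O)s1` — > 10000 nM

In an assay on membranes from brain for displacement of a labelled ligand from adenosine receptor A1 (Rattus norvegicus), read by scintillation counting, with a stated time of 90 min (a lower number here means a stronger inhibitor, a higher number a weaker inhibitor), compound 2 is the only one of the three to give a number, 229 nM. For compound 1 the value of > 10000 nM is a limit of the assay, not a number. For compound 3 the value of > 10000 nM is likewise a limit (the limit of > 10000 nM in this assay, at which 2 of the 3 values shown sit). The two steps that can be read, an at least 43-fold lower number from compound 1 to compound 2 (1.64 log units; beyond the scatter) and an at least 43-fold higher number from compound 2 to compound 3 (1.64 log units; beyond the scatter), both concern a halogen on an aromatic carbon of the shared core.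

Compound 4 `O=C(CCc1ccc(Cl)c(Cl)c1)Nc1nc2ccccc2c(=O)s1` differs from compound 2 in another place: 3,4-dichlorophenyl in place of benzyl on a saturated chain carbon, two bonds along the chain from a carbonyl carbon. Within the data shown here, none of the measured steps touches this chain position, so they give no direct guide to its size in this assay. The measured steps on the core ring do show that adding chlorine or bromine there drives the value to the limit, but a change on the chain is a different matter. Compound 4 is therefore estimated at 450 nM, with a range of 100 nM to 3000 nM, which means an expected step of a 2.0-fold higher number from compound 2 to compound 4 (0.29 log units; within the scatter).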

Compound 4, inhibition constant: > 1500 nM
Compound 4: a limit, no number; the forecaster's own chance of this, stated with the estimate: 15%; middle value at least 3.3-fold (0.52 log units) from the limit.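

In this assay, among these compounds, the earlier steps touched only the core, and this result shows that the chain position also matters: 3,4-dichlorophenyl in place of benzyl, on a saturated chain carbon, two bonds along the chain from a carbonyl carbon, gives an at least 6.5-fold higher number from compound 2 to compound 4 (0.81 log units; beyond the scatter). As far as these compounds go, compound 4 has a limit and not a number: the limit of > 1500 nM in this assay, at which 1 of the 4 values shown sits. The true size of this step therefore remains unknown, but a change away from the core can also weaken compound 2, as the chloro and bromo changes on the core do.

The compounds shown leave open whether the two chlorine atoms or the loss of the saturated carbon of benzyl accounts for this step, as the swap changes both at once. A plain phenyl at this place, or a benzyl carrying one chlorine or a methoxy group, would separate the two.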